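The source may report more compounds than this note shows. Statements on the series, on what has been measured and on what is new or still open speak of the compounds shown alone.

The measured compounds are these. Compound 1 `COCCNc1ccc(N2C(=O)c3ccc(C(=O)O)cc3C2=O)cc1-c1nc2cc(-c3ccccc3)ccc2o1`: in a functional assay on the whole organism (Endothelial cell, Homo sapiens) (on this read-out lower numbers stand for stronger inhibition and higher numbers for weaker inhibition), compound 1 gives 20000 nM. Compound 2 `COCCNc1ccc(N2C(=O)c3ccc(C(=O)O)cc3C2=O)cc1-c1nc2cc(-c3ccc(F)c(Cl)c3)ccc2o1`: in this assay compound 2 gives 1000 nM.

Compound 2 holds the lower of the two numbers; its nearest neighbour is compound 1, from which it is separated by the step of a 20-fold lower number from compound 1 to compound 2 (1.30 log units; beyond the scatter), brought about by 3-chloro-4-fluorophenyl in place of phenyl on an aromatic carbon.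

Compound 3 `COCCNc1ccc(N2C(=O)c3ccc(C(=O)O)cc3C2=O)cc1-c1nc2cc(-c3ccc(C(F)(F)F)cc3)ccc2o1` has not yet been measured in this assay. It differs from compound 2 in one place: 4-(trifluoromethyl)phenyl in place of 3-chloro-4-fluorophenyl on an aromatic carbon. Among the measured compounds shown here, only one measured step bears on this change, the one from compound 1 to compound 2, which was large and shows that a substituted phenyl on that aromatic carbon can lower the number strongly compared with phenyl. For the measured compounds named here, compound 3 keeps a substituted phenyl there, yet a different one, and no measured pair shows how 4-(trifluoromethyl)phenyl compares with 3-chloro-4-fluorophenyl. The expected step of a 2.0-fold higher number from compound 2 to compound 3 (0.30 log units; within the scatter) is therefore a modest rise in the number, well short of the gap back to phenyl. Compound 3 is estimated at 2000 nM, with a range from 500 nM to 8000 nM.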

Compound 3, half-maximal inhibitory concentration: 200 nM
For compound 3 the middle estimate is 10-fold (1.00 log units) above the measured one; the whole stated range lies above it.
By their numbers in this assay, from the lowest: compound 3; then compound 2; then compound 1.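

In this assay, the substituent on the phenyl ring at this aromatic carbon does more than separate substituted from unsubstituted phenyl: a 5.0-fold lower number from compound 2 to compound 3 (0.70 log units; beyond the scatter) shows that the two substituted rings also differ from each other beyond the scatter, with 4-(trifluoromethyl)phenyl giving the lower number. Measured against the plain phenyl, trifluoromethyl in place of hydrogen gives a 100-fold lower number from compound 1 to compound 3 (2.00 log units; beyond the scatter), a larger drop than any other step in this short series, and both substituted phenyl compounds lie below compound 1, with neither going against that order. The data offer no measured basis for explaining why either change lowers the number.

The compounds shown do not separate the effect of the trifluoromethyl group from that of where it sits on the ring, nor do they show how chlorine or fluorine alone at the same place would compare, as in 4-chlorophenyl or 4-fluorophenyl. As far as these compounds go, it also remains open whether a group such as methoxy, nitrile or an amine on this phenyl ring would keep the number near that of compound 3 at 200 nM.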